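Swapping chloro for bromo on compound 3

This account rests on a few compounds, and the source may have more. Where it says the series, first, only, none or still open, it means among the compounds named here.

Measured in a functional assay on DU-145 cells (Homo sapiens) for inhibition, read by trypan blue exclusion, with a stated time of 96 h (on this read-out lower numbers stand for stronger inhibition of growth and higher numbers for weaker inhibition of growth), so far:
compound 1 `Cc1ccc(CS(=O)(=O)/C(=C/c2ccc(S(C)(=O)=O)cc2)C(=O)c2ccc(Br)cc2)cc1` gives 10000 nM here
compound 2 `CSc1ccc(/C=C(\C(=O)c2ccc(Br)cc2)S(=O)(=O)Cc2ccc(F)cc2)cc1` gives 50000 nM here
compound 3 `CSc1ccc(/C=C(\C(=O)c2ccc(Cl)cc2)S(=O)(=O)Cc2ccc(C)cc2)cc1` gives 10000 nM here

Compound 3, at 10000 nM in this assay, is level with compound 1 at 10000 nM and these two share the lowest number of the three, while compound 2 reads higher at 50000 nM in the same test.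

Compound 4 `CSc1ccc(/C=C(\C(=O)c2ccc(Br)cc2)S(=O)(=O)Cc2ccc(C)cc2)cc1` differs from compound 3 in one place, with bromo in place of chloro on an aromatic carbon, para to a large group: bromo in place of chloro on an aromatic carbon is the whole change.

Within the data shown here, no measured pair shows this swap alone. Compound 1 at 10000 nM and compound 2 at 50000 nM both carry the 4-bromophenyl group, but they differ from compound 3 elsewhere, so they offer only loose guidance. In this assay no step beyond the scatter is expected, in either direction. The estimated 1.2-fold higher number from compound 3 to compound 4 (0.08 log units; within the scatter) should stay small. For compound 4 the estimate is 12000 nM with an expected range from 5000 nM to 30000 nM on repeat measurement.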

Compound 4, concentration for 50% growth inhibition: 10000 nM
For compound 4 the middle estimate is 1.2-fold (0.08 log units) above the measured one, and the stated range covers the measured number.
By their numbers in this assay, from the lowest: compounds 1, 3 and 4 (each within the scatter of the next); then compound 2.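

Bromo in place of chloro on the 4-chlorophenyl group gives, in this assay, no change at the digits printed from compound 3 to compound 4 (within the scatter) and is the first direct reading of this swap, so at this place the two halogens cannot be told apart. Among these compounds, compound 4 also gives two further single-change comparisons: methyl in place of fluoro on an aromatic carbon gives a 5.0-fold lower number from compound 2 to compound 4 (0.70 log units; beyond the scatter) and is the only one of the three steps beyond the scatter, whereas methylsulfanyl in place of methylsulfonyl gives no change at the digits printed from compound 1 to compound 4 (within the scatter). Nothing available here explains why these steps differ in size.

Going by these compounds, whether an amine or a methoxy group in place of the halogen would hold the same level remains open. Also open, on these data alone, is whether the methyl-for-fluoro step would be the same size with chloro in place of bromo.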